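Bromo for Methoxy in a Series Without Measured Growth Inhibition

The compounds below may be only part of what the source reports. "The series", "measured", "known", "first", "only" and "open" are said of these compounds alone.

Compound 1 `COc1ccccc1OCCNc1cnn(Cc2ccc(OC(F)F)c(OCC3CC3)c2)c(=O)c1Cl` gives > 100000 nM.
Compound 2 `COc1ccc(Cn2ncc(NCCOc3ccccc3OC)c(Cl)c2=O)cc1OC` gives > 100000 nM.
Compound 3 `COc1ccc(Cn2nc(NCCOc3ccccc3OC)ccc2=O)cc1OC` gives > 100000 nM.

All three values come from a functional assay on AGS cells (Homo sapiens) for antiproliferative activity, read by MTT assay, with a stated time of 48 h (a lower number here means a stronger inhibitor of growth, a higher number a weaker inhibitor of growth), and each is a limit of the assay rather than a number. Among the compounds with values here, compound 3 therefore stands at the same limit as the other two; (the limit of > 100000 nM in this assay, at which 3 of the 3 values shown sit), so no compound shows measurable growth inhibition and no ordering among them can be drawn. Compound 4 `COc1ccc(Cn2nc(NCCOc3ccccc3OC)ccc2=O)cc1Br` differs from compound 3 by bromo in place of methoxy on an aromatic carbon. Within the data shown here, with no measured step between compounds, and the shared core showing no activity here, the change is expected to move nothing beyond the scatter, so the step of a number no higher from compound 3 to compound 4 (the limit leaves the size open) is estimated to be flat. Compound 4 is therefore expected to give 100000 nM, within 40000 nM to 300000 nM, most likely again as a limit.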

Compound 4, concentration for 50% growth inhibition: > 100000 nM
Compound 4: only a limit was reported; the forecaster's own chance of this, stated with the estimate: 85%; the middle value sits exactly at the limit.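

Compound 3 and compound 4 both sit at a limit in this assay, so no step between them can be read: the limit of > 100000 nM in this assay, at which 4 of the 4 values shown sit.

The compounds shown leave open whether bromo in place of methoxy affects growth inhibition at all.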